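Swapping a thiophene for a pyridine on a shared chalcone core

A few compounds are considered here, and "the series" means these few. Any claim that something is new, unique, unknown or untested is made for them only; others in the source may bear on it.

Measured compounds:
compound 1, `COc1cc(C(=O)/C=C/c2cn(-c3ccccc3)nc2-c2ccsc2)cc(OC)c1OC`: 3200 nM
compound 2, `COc1ccc(C(=O)/C=C/c2cn(-c3ccccc3)nc2-c2ccsc2)cc1OC`: 1600 nM
compound 3, `COc1ccc(C(=O)/C=C/c2cn(-c3ccccc3)nc2-c2ccsc2)c(OC)c1`: 2200 nM

All three were tested in a functional assay on HCT-116 cells (Homo sapiens) for inhibition, read by sulforhodamine B assay, with a stated time of 72 h; on this read-out lower numbers stand for stronger inhibition and higher numbers for weaker inhibition. Compound 1 gives 3200 nM in this assay. The step of a 2.0-fold lower number from compound 1 to compound 2 (0.30 log units; within the scatter) lies within the scatter, and the step of a 1.4-fold higher number from compound 2 to compound 3 (0.14 log units; within the scatter) does too, so the three numbers cannot be told apart; compound 1 stands on level ground with compound 2 and compound 3 rather than apart from them.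

The unmeasured compound 4, `COc1cc(C(=O)/C=C/c2cn(-c3ccccc3)nc2-c2cccnc2)cc(OC)c1OC`, differs from compound 1 in one place: pyridin-3-yl in place of thiophen-3-yl on an aromatic carbon. Both measured steps change only the methoxy pattern on the aromatic ring attached to the carbonyl carbon; neither touches the five-membered aromatic ring with 2 nitrogen or the group that sits on it. Among the measured compounds shown here, there is thus no measured step that bears on the exchange of thiophen-3-yl for pyridin-3-yl, and the small size of both known steps gives no hint of a sensitive position anywhere.

On that basis no step beyond the scatter is expected, and a 1.1-fold higher number from compound 1 to compound 4 (0.04 log units; within the scatter) is the estimated change. Compound 4 is therefore expected to give about 3500 nM in this assay, with a range from 1000 nM to 12000 nM.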

Compound 4, half-maximal inhibitory concentration: 8600 nM
Beside the measured number, compound 4's estimate is 2.5-fold (0.39 log units) below it; measured number inside the range.
By their numbers in this assay, from the lowest: compounds 2, 3 and 1 (each within the scatter of the next); then compound 4.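

Among the compounds shown here, the place on the five-membered aromatic ring with 2 nitrogen, next to the ring nitrogen, is the first where a single exchange moves the number beyond the scatter: in this assay, putting pyridin-3-yl in place of thiophen-3-yl gives a 2.7-fold higher number from compound 1 to compound 4 (0.43 log units; beyond the scatter). So this position is not as indifferent as the methoxy changes among compounds 1, 2 and 3 suggested, although the shift toward weaker inhibition is modest. The exchange swaps a five-membered ring holding sulfur for a six-membered ring holding nitrogen, while the counted hydrogen-bond donors, hydrogen-bond acceptors and net charge stay the same, and no supporting measurement is available to explain the shift.

With a single exchange at this place, ring size and the identity of the hetero atom cannot be separated, and a furan-3-yl or a pyridin-4-yl group on the same carbon would be needed to begin telling them apart. As far as these compounds go, it also remains open whether pyridin-3-yl has a similar effect alongside the two dimethoxyphenyl patterns of compound 2 and compound 3.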